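This account rests on a few compounds, and the source may have more. Where it says the series, first, only, none or still open, it means among the compounds named here.

Among the measured compounds shown here, compound 1 `N#Cc1ccc(-c2ccc(/C=N/N3C(=O)NC(=O)C3O)o2)cc1` in a functional assay on the whole organism for activation, with Mus musculus as the target, with a stated time of 60 min (a lower number here means that less compound is needed, a higher number that more compound is needed for the effect), gives 156 mg/kg, the lower of the two numbers measured so far, though that ranking is not secure. Compound 2 `O=C1NC(=O)N(/N=C/c2ccc(-c3cccc(C(F)(F)F)c3)o2)C1O` in this assay gives 244 mg/kg, which lies within the scatter of compound 1, so the two cannot be separated. Compound 3 `O=C1NC(=O)N(/N=C/c2ccc(-c3ccc(F)cc3)o2)C1O` differs from compound 1 in one place: fluoro in place of cyano on an aromatic carbon. For the measured compounds named here, no two measured compounds differ in a single place, so no measured step guides this change; I expect a step no larger than the scatter. Compound 3 is expected to give 180 mg/kg, somewhere between 90 mg/kg and 360 mg/kg, meaning a step of a 1.2-fold higher number from compound 1 to compound 3 (0.06 log units; within the scatter).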

Compound 3, dose for half-maximal effect: 1000 mg/kg
The estimate for compound 3 lay 5.6-fold (0.74 log units) below the measured number; the measured number lies above the stated range.
By their numbers in this assay, from the lowest: compounds 1 and 2 (each within the scatter of the next); then compound 3.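

In this assay, among the compounds shown here, the aromatic carbon para to a large group proves sensitive to what it carries: fluoro in place of cyano is the first single-place change here, and it moves the result beyond the scatter (a 6.4-fold higher number from compound 1 to compound 3 (0.81 log units; beyond the scatter)). Much more compound is needed for the effect once cyano leaves. No available measurement explains why this step occurs.

A single step cannot show whether cyano is unusually favourable or fluoro unusually poor. An amine or a carboxylic acid on the same aromatic carbon could help separate these two readings.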